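The source may hold more compounds than are shown below. What is called first, only, known or untested is meant among the compounds shown, and "the series" means these compounds.

Measured compounds in an ADME assay on MT4 cells (Homo sapiens) for cytotoxicity, read by MTT assay, with a stated time of 4 days; a higher number here means that more compound is tolerated, a lower number that less compound is tolerated:
- compound 1 `CCOC(=O)c1cnc(N2CCN(Cc3ccc(C#N)cc3)CC2)nc1Oc1c(C)cc(-c2ccc(C#N)cc2)cc1C`: > 125000 nM
- compound 2 `CCOC(=O)c1cnc(N2CCN(Cc3ccccc3C(F)(F)F)CC2)nc1Oc1c(C)cc(-c2ccc(C#N)cc2)cc1C`: > 125000 nM
- compound 3 `CCOC(=O)c1cnc(N2CCN(Cc3ccccc3C(=O)OC)CC2)nc1Oc1c(C)cc(-c2ccc(C#N)cc2)cc1C`: > 125000 nM

Compound 1 sits at a limit of this assay, not at a number. The same is true of compound 2, and again of compound 3. All three values rest on (the limit of > 125000 nM in this assay, at which 3 of the 3 values shown sit), so the steps a step that the two limits leave unreadable from compound 1 to compound 2 and a step that the two limits leave unreadable from compound 1 to compound 3 cannot be read in size.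

Compound 4 `CCOC(=O)c1cnc(N2CCN(Cc3ccc(Br)cc3)CC2)nc1Oc1c(C)cc(-c2ccc(C#N)cc2)cc1C` differs from compound 1 by bromo in place of cyano on an aromatic carbon. Going by the values given here, no measured step bears on this change with a readable size, and the three measured compounds give no sign of a difference in this assay.

Compound 4 is therefore expected to show a step that the limit leaves unreadable from compound 1 to compound 4, none beyond the scatter. The estimate for compound 4 is 150000 nM, with a range from 60000 nM to 400000 nM.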

Compound 4, half-maximal cytotoxic concentration: > 125000 nM
Compound 4: no number, only a limit (the forecaster's own chance of this, stated with the estimate: 85%); the middle value is on the limit's open side.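

Going by these compounds alone, compound 4 gives > 125000 nM as a limit and not a number, so no step linking it with compound 1, compound 2 or compound 3 can be read: the limit of > 125000 nM in this assay, at which 4 of the 4 values shown sit.

As far as these compounds go, the concentration at which any of these four compounds would become cytotoxic in this assay remains open.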